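The source may hold more compounds than are shown below. What is called first, only, known or untested is meant among the compounds shown, and "the series" means these compounds.

Among the compounds with values here, in an ADME assay on HaCaT cells (Homo sapiens) for inhibition, read by sulforhodamine B assay, with a stated time of 48 h (on this read-out lower numbers stand for stronger inhibition of growth and higher numbers for weaker inhibition of growth), compound 3 `CC(C)(C)NCc1c(C(=O)O)nn(-c2ccccc2)c1-c1ccc(Br)cc1` gives 366000 nM, and it is the only compound here with a single plain number. Compound 2 `CC(C)(C)NCc1c(C(=O)O)nn(-c2ccccc2)c1-c1ccc(Cl)cc1` reads > 652000 nM, which is a limit of the assay. Compound 1 `CCOC(=O)c1nn(-c2ccccc2)c(-c2ccc(Br)cc2)c1CNC(C)(C)C` gives 61700 nM; > 509000 nM (2 entries), entries that do not agree, so they offer no firm anchor.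

The compound still to be measured is compound 4 `Cc1ccc(-c2c(CNC(C)(C)C)c(C(=O)O)nn2-c2ccccc2)cc1`. It differs from compound 3 by methyl in place of bromo on an aromatic carbon, so that 4-bromophenyl becomes 4-methylphenyl. Within the data shown here, one measured step touches the same place, bromo in place of chloro, and it reads an at least 1.7-fold lower number from compound 2 to compound 3 (0.25 log units; that floor lies within the scatter). Among the measured compounds shown here, with only that step to go on, no change beyond the scatter is expected in this assay, though a slightly higher number seems the likelier side. The expected change is a 1.2-fold higher number from compound 3 to compound 4 (0.09 log units; within the scatter). Compound 4 is estimated at 450000 nM, with an expected range from 190000 nM to 950000 nM.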

Compound 4, concentration for 50% growth inhibition: > 688000 nM
Compound 4: no number, only a limit (the forecaster's own chance of this, stated with the estimate: 40%); middle value at least 1.5-fold (0.18 log units) from the limit.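

In this assay, methyl in place of bromo on this aromatic carbon gives an at least 1.8-fold higher number from compound 3 to compound 4 (0.27 log units; that floor lies within the scatter), so even this floor does not separate the two compounds. Compound 4 yields no number, only a limit of the assay: the limit of > 688000 nM in this assay, at which 1 of the 4 values shown sits. The step from compound 2 to compound 4 cannot be read, and compound 3 remains the only carboxylic acid here with a plain number.

Going by these compounds, how far compound 4 truly lies from compound 3 remains unknown, as does any firm order among the chloro, bromo and methyl compounds. Also open, on these data alone, is whether a methoxy group, a nitrile or a longer chain such as ethyl on this aromatic carbon would give a plain number in this assay.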